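Swapping a fluorinated phenyl for a fluorinated pyridine

The source may hold more compounds than are shown below. What is called first, only, known or untested is meant among the compounds shown, and "the series" means these compounds.

Three compounds share a core in which an amide-linked tetrazole carries an aromatic group. Compound 1 `Cc1cc(NC(=O)Cn2nnc(-c3ccccn3)n2)n(C2CCCCC2)n1` bears a pyridin-2-yl there and gives 81% in an assay on HEK293 cells for activation of Kir3.1/Kir3.2 (Homo sapiens), read by thallium flux; on this read-out lower numbers stand for smaller maximal responses and higher numbers for larger maximal responses. Compound 2 `Cc1cc(NC(=O)Cn2nnc(-c3ccc(F)cc3)n2)n(C2CCCCC2)n1` carries a 4-fluorophenyl and gives 92%; compound 3 `Cc1cc(NC(=O)Cn2nnc(-c3ccc(F)c(F)c3)n2)n(C2CCCCC2)n1` carries a 3,4-difluorophenyl and gives 93%. Compound 3 and compound 2 cannot be told apart, since a number 1 percentage points higher from compound 2 to compound 3 (within the scatter); both stand beyond the scatter above compound 1, as a number 11 percentage points higher from compound 1 to compound 2 (beyond the scatter) and a number 12 percentage points higher from compound 1 to compound 3 (beyond the scatter).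

Compound 4 `Cc1cc(NC(=O)Cn2nnc(-c3cccc(F)n3)n2)n(C2CCCCC2)n1` differs from compound 3 in one place: 6-fluoropyridin-2-yl in place of 3,4-difluorophenyl on an aromatic carbon. Among the measured compounds shown here, two measured steps bear on it. The step from the pyridin-2-yl to the 3,4-difluorophenyl gave a number 12 percentage points higher from compound 1 to compound 3 (beyond the scatter), and the reverse direction is taken here, so a drop of similar size is expected. The added fluoro is unlikely to offset that, because a number 1 percentage points higher from compound 2 to compound 3 (within the scatter). Compound 4 is therefore expected to show a number 10 percentage points lower from compound 3 to compound 4 (within the scatter), giving an estimate of 83% with a range from 72% to 94%.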

Compound 4, largest response reached (Emax), in percent of the reference or control that the assay uses: > 83%
Compound 4 ended at the assay's limit; the forecaster's own chance of this, stated with the estimate: 2%; the middle value lies on the limit itself.
By their numbers in this assay, from the lowest: compound 1; then compounds 2 and 3 (each within the scatter of the next).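

In this assay compound 4 gives > 83%, which is a limit of the assay and not a number. Among the compounds shown here, its steps from compound 2 and compound 3 cannot be read, so the 6-fluoropyridin-2-yl cannot yet be ranked against either fluorinated phenyl group, and the only readable step, a number at least 2 percentage points higher from compound 1 to compound 4 (that floor lies within the scatter), gives a floor rather than a size. What is new is that adding a fluoro can now be compared on a phenyl and on a pyridin-2-yl group: the same change on two cores in this assay, a number 1 percentage points higher (within the scatter) from compound 2 to compound 3 and a number at least 2 percentage points higher (that floor lies within the scatter) from compound 1 to compound 4; the limit leaves it open whether they differ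

Going by these compounds, it remains open whether the fluoro on the pyridin-2-yl group raises the response beyond the scatter, since a floor cannot settle that. Also open, on these data alone, is how this position responds to a methoxy group or an amine on the pyridin-2-yl ring in place of the fluoro.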